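Shortening the acid chain and adding a double bond

This account rests on a few compounds, and the source may have more. Where it says the series, first, only, none or still open, it means among the compounds named here.

Measured so far:
- compound 1, `COc1ccc(COCC(Cn2ccnc2)OCCCCCC(=O)O)cc1`: 560 nM
- compound 2, `CCOC(=O)CCCCCOC(COCc1ccc(OC)cc1)Cn1ccnc1`: 120 nM
- compound 3, `COc1ccc(COCC(Cn2ccnc2)OCCCCCCC(=O)O)cc1`: 1890 nM

All three share one core and differ only in the chain carrying the acid. In a functional assay on a cell-free system (plasma) for inhibition of Thromboxane-A synthase (Homo sapiens) (on this read-out lower numbers stand for stronger inhibition and higher numbers for weaker inhibition), compound 3 gives the highest number of the three; the steps leading up to it are a 3.4-fold higher number from compound 1 to compound 3 (0.53 log units; beyond the scatter) and a 16-fold higher number from compound 2 to compound 3 (1.20 log units; beyond the scatter). Between the other two, there is also a 4.7-fold lower number from compound 1 to compound 2 (0.67 log units; beyond the scatter).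

Compound 4, `COc1ccc(COCC(Cn2ccnc2)OCCC/C=C/C(=O)O)cc1`, has not yet been measured. Its difference from compound 3 is 2-carboxyethenyl in place of 3-carboxypropyl on a saturated chain carbon, three bonds along the chain from an oxygen on a saturated carbon. Among the measured compounds shown here, the chain thus becomes one carbon shorter, matching the length of compound 1, and gains a double bond that no measured compound carries.

For the measured compounds named here, only one measured step bears directly on this: the chain lengthening from compound 1 to compound 3 raised the number, so reversing that length is expected to lower it again. Going by the values given here, no measured step speaks to the double bond. The expected step is therefore a 3.2-fold lower number from compound 3 to compound 4 (0.50 log units; beyond the scatter) in this assay, with wide uncertainty. Compound 4 is estimated at 600 nM in this assay, within a range from 150 nM to 2500 nM.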

Compound 4, half-maximal inhibitory concentration: 8330 nM
Compound 4: the middle estimate sits 14-fold (1.14 log units) below what was measured; measured number above the stated range.
By their numbers in this assay, from the lowest: compound 2; then compound 1; then compound 3; then compound 4.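

The comparison that isolates the double bond is with compound 1, whose 2-carboxyethyl chain differs from the 2-carboxyethenyl chain of compound 4 only by that bond, and in this assay this change alone weakens inhibition (a 15-fold higher number from compound 1 to compound 4 (1.17 log units; beyond the scatter)). Matching the chain of compound 1 in length therefore does not bring back its potency: the change from 3-carboxypropyl to 2-carboxyethenyl gives a higher number, not a lower one (a 4.4-fold higher number from compound 3 to compound 4 (0.64 log units; beyond the scatter)), so chain length alone does not set the number at this position. The ester compound 2 and compound 4 now mark the two ends of this small set (a 69-fold higher number from compound 2 to compound 4 (1.84 log units; beyond the scatter)), which shows how much the number can move through changes in this one chain, with the saturated ethyl ester at the strong end and the unsaturated acid at the weak end.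

Still open, as far as these compounds go, is whether an ethyl ester on the 2-carboxyethenyl chain would lower the number as it does on the saturated chain, and whether the opposite double-bond geometry or a triple bond in the same place would cost as much. Nothing available explains why the double bond raises the number.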